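Compound 3 and the Hydroxy Change

A few compounds are considered here, and "the series" means these few. Any claim that something is new, unique, unknown or untested is made for them only; others in the source may bear on it.

Measured in a functional assay on 786-0 cells (Homo sapiens) for inhibition, read by sulforhodamine B assay, with a stated time of 48 h; a lower number here means a stronger inhibitor of growth, a higher number a weaker inhibitor of growth:
Compound 1 `CC1(/C=C/c2ccccc2)C=CC(=O)O1`: 170000 nM
Compound 2 `CC1(/C=C/c2ccc(F)cc2)C=CC(=O)O1`: 101000 nM

Only these two compounds have been measured so far. Compound 1, at 170000 nM, stands within the scatter of compound 2, so the two cannot be told apart on these numbers.

The next compound to be measured is compound 3 `CC1(/C=C/c2ccccc2O)C=CC(=O)O1`. It differs from compound 1 by hydroxy in place of hydrogen on an aromatic carbon, which in words is hydroxy in place of hydrogen on an aromatic carbon.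

Going by the values given here, the one measured step that bears on this change, also a replacement of hydrogen on an aromatic carbon, is a 1.7-fold lower number from compound 1 to compound 2 (0.23 log units; within the scatter), and it sets the expected size. Among the compounds with values here, it is only a loose guide, since fluoro is a different group and no measured compound carries hydroxy. No step beyond the scatter is therefore expected in this assay, and the data give no firm direction.

The estimated step is a 1.3-fold lower number from compound 1 to compound 3 (0.12 log units; within the scatter). For compound 3 the expected value is 130000 nM, with an estimated range of 50000 nM to 260000 nM.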

Compound 3, concentration for total growth inhibition: 136000 nM
For compound 3 the middle estimate is 1.0-fold (0.02 log units) below the measured one; the range from low to high includes it.
By their numbers in this assay, from the lowest: compounds 2, 3 and 1 (each within the scatter of the next).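

Swapping hydrogen for hydroxy, ortho to a group of 9 heavy atoms, gives a 1.3-fold lower number from compound 1 to compound 3 (0.10 log units; within the scatter) in this assay, so compound 3 cannot be told apart from compound 1 on these numbers. This adds a group with a hydrogen-bond donor and a hydrogen-bond acceptor to the picture, and the earlier fluoro replacement, a 1.7-fold lower number from compound 1 to compound 2 (0.23 log units; within the scatter), is also within the scatter, so neither of the two replacements of hydrogen on this aromatic ring shifts the number by more than repeated measurements would. Nothing available here explains why the hydroxy change makes so little difference.

The compounds shown leave open whether any group on this aromatic carbon can move the number beyond the scatter, for example an amine, a carboxylic acid or a methoxy group. They also leave open whether hydroxy would behave the same way on another carbon of the ring, and whether changes to the shared core outside this ring would matter more than those made on it.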